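This account rests on a few compounds, and the source may have more. Where it says the series, first, only, none or still open, it means among the compounds named here.

Compound 2 `Cc1nc(N(C)C)nc(N[C@@H]2C[C@H](CO)[C@@H](O)[C@H]2O)c1-c1nc2ccccc2s1` holds the highest of the two numbers measured in an ADME assay on cells (Homo sapiens) for cytotoxicity, read by polymerase chain reaction, with a stated time of 3 days (a higher number here means that more compound is tolerated, a lower number that less compound is tolerated), giving 18000 nM. Compound 1 `CNc1ccc2nc(-c3c(Cl)nc(N)nc3N[C@@H]3C[C@H](CO)[C@@H](O)[C@H]3O)sc2c1` gives 6000 nM in this assay, a lower number that lies beyond the usual scatter. Compound 3 `CCc1nc(N(C)C)nc(N[C@@H]2C[C@H](CO)[C@@H](O)[C@H]2O)c1-c1nc2ccccc2s1` is reported only at a limit, > 25000 nM, which is the limit of > 25000 nM in this assay, at which 1 of the 3 values shown sits. Among the measured compounds shown here, the single measured step, an at least 1.3-fold higher number from compound 2 to compound 3 (0.14 log units; that floor lies within the scatter), concerns a methyl on a saturated chain carbon and not the position changed here. Compound 4 `Cc1nc(Nc2ncco2)nc(N[C@@H]2C[C@H](CO)[C@@H](O)[C@H]2O)c1-c1nc2ccccc2s1` differs from compound 2 by (1,3-oxazol-2-yl)amino in place of dimethylamino on an aromatic carbon. For the measured compounds named here, no measured step bears on this change, so no step beyond the scatter is expected, and compound 4 is estimated at 15000 nM with a range from 5000 nM to 40000 nM, an expected step of a 1.2-fold lower number from compound 2 to compound 4 (0.08 log units; within the scatter).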

Compound 4, half-maximal cytotoxic concentration: > 25000 nM
Compound 4 was reported as a limit (the forecaster's own chance of this, stated with the estimate: 25%); middle value at least 1.6-fold (0.22 log units) away from the limit.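

At this aromatic carbon between two ring nitrogen atoms, (1,3-oxazol-2-yl)amino in place of dimethylamino gives an at least 1.3-fold higher number from compound 2 to compound 4 (0.14 log units; that floor lies within the scatter) in this assay. The position therefore carries a five-membered aromatic ring and a hydrogen-bond donor without any lower number appearing. Compound 4 is reported only at a limit, so the full size of this step cannot be read: the limit of > 25000 nM in this assay, at which 2 of the 4 values shown sit.

Going by these compounds, whether a morpholine or a carboxylic acid on this carbon would also reach that limit remains open. The number that compound 4 would give beyond the limit is also unknown.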